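This account rests on a few compounds, and the source may have more. Where it says the series, first, only, none or still open, it means among the compounds named here.

In an ADME assay on the whole organism (strain Sprague-Dawley) for pharmacokinetics, with Rattus norvegicus as the target, read by LC-MS, using cassette dosing, at a dose of 0.5 mg/kg by the intravenous route (on this read-out higher numbers stand for fast clearance and lower numbers for slow clearance), compound 1 (`C[C@@]1(c2cc(NC(=O)c3cnc(OCF)cn3)ccc2F)C=C(CF)OC(N)=N1`) gives 34.4 mL/min/kg. This places it level with compound 2 (`C[C@@]1(c2cc(NC(=O)c3ncc(C#N)cc3Cl)ccc2F)C=C(CF)OC(N)=N1`), at 30.6 mL/min/kg, and with compound 3 (`C[C@@]1(c2cc(NC(=O)c3coc(C(F)F)n3)ccc2F)C=C(CF)OC(N)=N1`), at 28.4 mL/min/kg. Compound 4 (`C[C@@]1(c2cc(NC(=O)c3cnc(C(F)F)cn3)ccc2F)C=C(CF)OC(N)=N1`) departs from compound 1 in one place: difluoromethyl in place of fluoromethoxy on an aromatic carbon. In other words, 5-(fluoromethoxy)pyrazin-2-yl becomes 5-(difluoromethyl)pyrazin-2-yl. The closest measured evidence is a 1.1-fold lower number from compound 1 to compound 2 (0.05 log units; within the scatter) and a 1.2-fold lower number from compound 1 to compound 3 (0.08 log units; within the scatter), each within the scatter, although both replace the whole group on the carbonyl carbon and neither isolates this change. From these two steps, no shift beyond the scatter is expected in this assay. The expected step is a 1.1-fold lower number from compound 1 to compound 4 (0.06 log units; within the scatter), which stays within the scatter. Compound 4 is estimated at 30 mL/min/kg, with an expected range of 17 mL/min/kg to 52 mL/min/kg.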

Compound 4, clearance: 48.1 mL/min/kg
The estimate for compound 4 lay 1.6-fold (0.21 log units) below the measured number; measured number inside the range.
By their numbers in this assay, from the lowest: compounds 3, 2, 1 and 4 (each within the scatter of the next).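

Compound 4 isolates this change at the pyrazine position in this assay: difluoromethyl in place of fluoromethoxy gives a 1.4-fold higher number from compound 1 to compound 4 (0.15 log units; within the scatter) and so leaves the number within the scatter. The 5-(difluoromethyl)pyrazin-2-yl amide also stays within the scatter of the other two amides, with a 1.7-fold higher number from compound 3 to compound 4 (0.23 log units; within the scatter) and a 1.6-fold higher number from compound 2 to compound 4 (0.20 log units; within the scatter) as its steps. No measurement shown here accounts for these numbers. The compounds shown leave open whether an amine or a longer alkoxy chain at this position would move clearance beyond the scatter.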